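The source may report more compounds than this note shows. Statements on the series, on what has been measured and on what is new or still open speak of the compounds shown alone.

Compound 3 `CCc1cc(C(C)=O)c(O)cc1OCCCCCCCC(C)(C)C#N` stands lowest among the three compounds measured in an assay on isolated protein for inhibition of leukotriene B4 receptor 1 (Homo sapiens), tested at 10 uM (on this read-out higher numbers stand for more inhibition at the one concentration tested (going by the name of the read-out) and lower numbers for less inhibition), where compound 3 gives 66%; compound 2 `CCc1cc(C(C)=O)c(O)cc1OCCCCCC(C)(C)C#N` gives 85% and compound 1 `CCc1cc(C(C)=O)c(O)cc1OCCCCC#N` gives 92%. The lengthening steps ran downward, a number 26 percentage points lower from compound 1 to compound 3 (beyond the scatter) and a number 19 percentage points lower from compound 2 to compound 3 (beyond the scatter), while a number 7 percentage points lower from compound 1 to compound 2 (within the scatter). Within the data shown here, compound 4 `CCc1cc(C(C)=O)c(O)cc1OCCCCCC(C)(C)c1nnn(C)n1` carries 1-methyl-1-(2-methyl-2H-tetrazol-5-yl)ethyl in place of 3-cyano-3-methylbutyl on a saturated chain carbon, five bonds along the chain from an oxygen on an aromatic ring, so the chain returns to the length of compound 2 while a nitrile is exchanged for a methyl-tetrazole; no measured step covers that exchange. Resting on the shortening alone, compound 4 is expected to rise by a number 12 percentage points higher from compound 3 to compound 4 (beyond the scatter) in this assay, and its inhibition is estimated at 78%, in the range 58% to 93%.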

Compound 4, a percentage reported as inhibition, at one concentration (the size of the read-out at that concentration, not a potency): 95%
Beside the measured number, compound 4's estimate is 17 percentage points below it, outside the stated range (above it).
By their numbers in this assay, from the lowest: compound 3; then compounds 2, 1 and 4 (each within the scatter of the next).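

On a saturated chain carbon bound to three saturated chain carbons, 2-methyl-2H-tetrazol-5-yl takes the place of cyano with no change beyond the scatter (a number 10 percentage points higher from compound 2 to compound 4 (within the scatter)), so this position accepts a five-membered aromatic ring with 4 hetero atoms as well as a nitrile. The step that also shortens the chain (a number 29 percentage points higher from compound 3 to compound 4 (beyond the scatter)) restores the inhibition lost in compound 3. Nothing available explains either step. Still open, on these data alone, is whether a carboxylic acid or an amine at this chain end would keep that inhibition, and whether the methyl-tetrazole would hold on the longer chain of compound 3.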